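Saturating the cyclohexenyl ring on the alkyne-linked phenylpropanoic acid

The source may hold more compounds than are shown below. What is called first, only, known or untested is meant among the compounds shown, and "the series" means these compounds.

Measured so far:
compound 1, `O=C(O)CCc1ccc(C#CC2=CCCCC2)cc1` — 100%
compound 2, `C/C(C#Cc1ccc(CCC(=O)O)c(F)c1)=C/CO` — 105%

Two compounds share the core and carry a full agonist response in a functional assay on 1321-N1 cells for agonist activity at Free fatty acid receptor 1 (Homo sapiens), read by calcium flux, with a stated time of 0.4 s; a lower number here means a smaller maximal response, a higher number a larger maximal response. In this assay compound 1 gives 100%, the lower of the two numbers; compound 2 gives 105%, a difference that lies within the usual scatter, so the two are not distinguished by these data.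

Compound 3, `O=C(O)CCc1ccc(C#CC2CCCCC2)cc1`, differs from compound 1 by cyclohexyl in place of cyclohex-1-en-1-yl on a triple-bonded carbon. Among the compounds with values here, no measured pair in this set reports such a change, so there is no step to draw on. A group of the same size and ring count enters, and the shared acid and aromatic part stay as they are. The expected step from compound 1 to compound 3 in this assay is a number 4 percentage points lower from compound 1 to compound 3 (within the scatter), within the scatter, without a clear direction. For compound 3 the estimated efficacy is 96%, with a range from 78% to 114%.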

Compound 3, largest response reached (reported as efficacy), in percent of the reference or control that the assay uses: 98%
The estimate for compound 3 lay 2 percentage points below the measured number, and the stated range covers the measured number.
By their numbers in this assay, from the lowest: compounds 3, 1 and 2 (each within the scatter of the next).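

In this assay, within the data shown here, cyclohexyl in place of cyclohex-1-en-1-yl on a triple-bonded carbon gives a number 2 percentage points lower from compound 1 to compound 3 (within the scatter), the first single-place step. The double bond of the cyclohex-1-en-1-yl ring is therefore not needed to keep the maximal response in this pair, and compound 3 is not distinguished from compound 1 by this read-out. Nothing measured here speaks to the reason for this result.

The compounds shown report only the largest response reached, so they leave potency at this receptor open. Also open, as far as these compounds go, is whether a group of another kind on the same triple-bonded carbon, such as a phenyl ring, a longer alkyl chain or an amine, would preserve the response seen with both six-membered carbon rings.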